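The source may hold more compounds than are shown below. What is called first, only, known or untested is meant among the compounds shown, and "the series" means these compounds.

Of the compounds shown here, three sharing one core have been measured in an assay for inhibition of Myeloperoxidase (Homo sapiens), read by Amplex Red, with stated times of 10 min and 15 min; on this read-out higher numbers stand for weaker inhibition and lower numbers for stronger inhibition. Compound 1 `Nc1cc(OCc2ccccc2-n2cccn2)c2nn[nH]c2n1` gives 26 nM, compound 2 `Nc1cc(OCc2cccc(Cl)c2)c2nn[nH]c2n1` gives 21 nM and compound 3 `Nc1cc(OCc2ccc(Cl)cc2)c2nn[nH]c2n1` gives 26 nM. Compound 2 has the lowest number of the three, yet its distances to compound 1 and to compound 3 both lie within the scatter, so the three stand together.

Compound 4 `Nc1cc(OCc2cccc(-c3ccccc3F)c2)c2nn[nH]c2n1` has not been measured in this assay . It differs from compound 2 in a single place: 2-fluorophenyl in place of chloro on an aromatic carbon, on an aromatic carbon of a six-membered aromatic ring of carbon only, meta to a large group. Going by the values given here, no measured pair shows such a change, so the step of a 1.4-fold higher number from compound 2 to compound 4 (0.15 log units; within the scatter) is an expectation only, given as small and of uncertain direction. Compound 4 is estimated at 30 nM, within 10 nM to 100 nM.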

Compound 4, half-maximal inhibitory concentration: 160 nM
For compound 4 the middle estimate is 5.3-fold (0.73 log units) below the measured one; the measured number lies above the stated range.
By their numbers in this assay, from the lowest: compounds 2, 1 and 3 (each within the scatter of the next); then compound 4.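

In this assay, going by these compounds alone, the aromatic carbon meta to a large group proves sensitive to what it carries: 2-fluorophenyl in place of chloro gives a 7.6-fold higher number from compound 2 to compound 4 (0.88 log units; beyond the scatter), the first step to lie beyond the scatter. This place therefore does not accept every group alike. Nothing at hand gives a reason for the loss.

As far as these compounds go, whether the loss belongs to the added ring or to its fluorine stays open. So does how plain phenyl, methyl or a phenyl carrying an amine would fare at this place.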